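Compound 1 to compound 3: nitro for carbamoyl

This account rests on a few compounds, and the source may have more. Where it says the series, first, only, none or still open, it means among the compounds named here.

Values so far in a physicochemical assay for lipophilicity, at pH 7.4 (a higher number here means a more lipophilic compound, a lower number a more polar compound), as follows
- compound 1 `Cc1cc(/C=C/C#N)cc(C)c1Oc1cc(Nc2ccc(C#N)cc2)c(N)cc1C(N)=O` gives 3.53
- compound 2 `CC(=O)CCc1cc(C)c(Oc2cc(Nc3ccc(C#N)cc3)c(N)cc2C(F)(F)F)c(C)c1` gives > 5 (a limit of the assay, not a number)

Within the data shown here, compound 1 holds the only actual number so far, at 3.53 on this scale. The reading for compound 2 is a limit only, so no gap to compound 1 can be sized.

Compound 3 `Cc1cc(/C=C/C#N)cc(C)c1Oc1cc(Nc2ccc(C#N)cc2)c(N)cc1[N+](=O)[O-]` is still to be measured. It has nitro in place of carbamoyl on an aromatic carbon and the rest of compound 1 is kept. The new group sits ortho to a large group, meta to an amino group and para to a (4-cyanophenyl)amino group.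

Among the measured compounds shown here, no step between measured compounds is available to scale this change, so the expectation rests on the structural change alone, starting from compound 1 at 3.53 in this assay as the anchor. An upward move beyond the usual scatter is expected, estimated as a number 0.97 log units higher from compound 1 to compound 3 (beyond the scatter) in size. For compound 3 the expected value is 4.5 with an estimated range from 4 to 5 on the same scale.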

Compound 3, partition coefficient: > 5
Compound 3 ended at the assay's limit; the forecaster's own chance of this, stated with the estimate: 15%; at least 0.50 log units between middle value and limit.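

At the position ortho to a large group, meta to an amino group and para to a (4-cyanophenyl)amino group, the series now has its first step in this assay, for nitro in place of carbamoyl with the rest of the core of compound 1 kept: the step is a number at least 1.47 log units higher from compound 1 to compound 3 (beyond the scatter). In this assay compound 3 gives > 5, which is a limit of the assay and not a number, so the step has a lower bound and no full size. With carbamoyl at this position swapped for nitro, the reading leaves the measurable range, and the scale offers little room for further comparison in this series: the limit of > 5 in this assay, at which 2 of the 3 values shown sit.

Going by these compounds, how far compound 3 lies past the limit remains open, and neither compound 3 nor compound 2 can be ranked against the other, as neither has a number. Also open, on these data alone, is where a carboxylic acid or a methyl ester at this position would read in this assay, whether on the scale near compound 1 or at the limit.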